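The source may report more compounds than this note shows. Statements on the series, on what has been measured and on what is new or still open speak of the compounds shown alone.

Three compounds of this series have been run in an ADME assay on Vero cells (Chlorocebus sabaeus) for cytotoxicity, read by MTT assay, with a stated time of 2 days; a lower number here means a stronger inhibitor, a higher number a weaker inhibitor. Compound 1 `CCCCSc1cc2[nH]c(C3CCCCC3)nc2cc1NC(=O)OCCC` gives 75000 nM. Compound 3 `Cc1ccc(C(=O)Nc2cc3nc(C4CCCCC4)[nH]c3cc2Sc2ccccc2)cc1` gives 6250 nM. Compound 2 `C=CCCC(=O)Nc1cc2nc(C3CCCCC3)[nH]c2cc1Oc1ccc(F)cc1` gives only a limit of the assay, > 200000 nM, and so stands at the limit of > 200000 nM in this assay, at which 1 of the 3 values shown sits. Compound 4 `O=C(Nc1cc2nc(C3CCCCC3)[nH]c2cc1Oc1ccc(F)cc1)c1ccc(F)cc1F` has not yet been measured; it differs from compound 2 in one place: 2,4-difluorophenyl in place of but-3-en-1-yl on a carbonyl carbon. Among the compounds with values here, no step between measured compounds is available, so the size of the change from compound 2 to compound 4 can only be expected. Compound 3, which also carries a six-membered aromatic ring of carbon only on its carbonyl carbon, gives 6250 nM, and on that basis compound 4 is expected to be a stronger inhibitor than compound 2, with an estimated step of an at least 5.0-fold lower number from compound 2 to compound 4 (0.69 log units; beyond the scatter). Compound 4 is estimated at 40000 nM, within 8000 nM to 200000 nM.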

Compound 4, half-maximal inhibitory concentration: > 200000 nM
Compound 4: a limit, no number; the forecaster's own chance of this, stated with the estimate: 30%; middle value at least 5.0-fold (0.69 log units) from the limit.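

Compound 2 and compound 4 both stand at a limit of the assay, so no step between them can be read: the limit of > 200000 nM in this assay, at which 2 of the 4 values shown sit.
From the compounds shown here alone, whether 2,4-difluorophenyl in place of but-3-en-1-yl on a carbonyl carbon changes the number at all, and by how much, stays open.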